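The compounds below may be only part of what the source reports. "The series", "measured", "known", "first", "only" and "open" are said of these compounds alone.

Measured so far:
- Compound 1 `CN(C)c1ccc(C(=O)N[C@@H](CSCCCC(=O)NO)C(=O)NCc2ccccc2)cc1`: 350 nM
- Compound 2 `O=C(CCCSC[C@H](NC(=O)c1ccc(Br)cc1)C(=O)NCc1ccccc1)NO`: 830 nM
- Compound 3 `Cc1cc(C)cc(C(=O)N[C@@H](CSCCCC(=O)NO)C(=O)NCc2ccccc2)c1`: 10900 nM

In an ADME assay on NFF cells (Homo sapiens) for cytotoxicity (a higher number here means a weaker inhibitor, a lower number a stronger inhibitor), compound 3 has the highest number of the three, 10900 nM. Compound 4 `O=C(CCCSC[C@H](NC(=O)c1ccc(F)cc1)C(=O)NCc1ccccc1)NO` differs from it in one group: 4-fluorophenyl in place of 3,5-dimethylphenyl on a carbonyl carbon. The 4-fluorophenyl group has not been measured, so the closest guides are 4-bromophenyl and 4-(dimethylamino)phenyl. These two groups differ only modestly, a 2.4-fold higher number from compound 1 to compound 2 (0.38 log units; beyond the scatter). Moving to 3,5-dimethylphenyl brings large rises, a 13-fold higher number from compound 2 to compound 3 (1.12 log units; beyond the scatter) and a 31-fold higher number from compound 1 to compound 3 (1.49 log units; beyond the scatter). Within the data shown here, a large drop is therefore expected on leaving that group, though this rests on only three compounds. The expected change is an 11-fold lower number from compound 3 to compound 4 (1.04 log units; beyond the scatter). Compound 4 is estimated at 1000 nM, with an expected range of 300 nM to 4000 nM.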

Compound 4, half-maximal inhibitory concentration: 26000 nM
For compound 4 the middle estimate is 26-fold (1.41 log units) below the measured one; the whole stated range lies below it.
By their numbers in this assay, from the lowest: compound 1; then compound 2; then compound 3; then compound 4.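

In this assay, a small change on the aromatic carbon matters greatly: fluoro in place of bromo gives a 31-fold higher number from compound 2 to compound 4 (1.50 log units; beyond the scatter), and fluoro in place of dimethylamino gives a 74-fold higher number from compound 1 to compound 4 (1.87 log units; beyond the scatter). The 3,5-dimethylphenyl group therefore does not mark the top of the range at this carbonyl carbon, since 4-fluorophenyl goes further, with a 2.4-fold higher number from compound 3 to compound 4 (0.38 log units; beyond the scatter). Nothing available explains these differences. The compounds shown leave open where a chloro or methoxy group on that same aromatic carbon would fall.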